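The source may hold more compounds than are shown below. What is called first, only, known or untested is meant among the compounds shown, and "the series" means these compounds.

Working notes on the series. Compound 1 `COc1cc(C(=N)NC(C)C)cc2cc(-c3ccc(C(=N)NC(C)C)cc3)oc12` is measured in an ADME assay on L6 cells (Rattus norvegicus) for cytotoxicity; on this read-out higher numbers stand for weaker inhibition and lower numbers for stronger inhibition; there compound 1 gives only a limit, > 190000 nM. Compound 3 `CC(C)NC(=N)c1ccc(-c2cc3cc(C(=N)NC(C)C)cc(O)c3o2)cc1` likewise gives only a limit in this assay, > 185000 nM. The change from compound 1 to compound 3 is hydrogen in place of methyl on an oxygen on an aromatic ring, and the step that the two limits leave unreadable from compound 1 to compound 3 cannot be read because the limit of > 190000 nM in this assay, at which 1 of the 3 values shown sits, and the limit of > 185000 nM in this assay, at which 1 of the 3 values shown sits, both cap the values. For the measured compounds named here, compound 2 `COc1cc(C2=NCCN2)cc2cc(-c3ccc(C4=NCCN4)cc3)oc12` gives 19900 nM in this assay, the only number in the set; the difference between the cores of compound 1 and compound 2 is not broken down here. Compound 4 `Oc1cc(C2=NCCN2)cc2cc(-c3ccc(C4=NCCN4)cc3)oc12` is not yet measured; it differs from compound 2 by hydrogen in place of methyl on an oxygen on an aromatic ring, the same change as from compound 1 to compound 3. Since that earlier step is unreadable, a small step of a 1.3-fold higher number from compound 2 to compound 4 (0.10 log units; within the scatter) is expected in this assay. Compound 4 is estimated at 25000 nM, between 8000 nM and 80000 nM.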

Compound 4, half-maximal inhibitory concentration: > 203000 nM
Compound 4 ended at the assay's limit; the forecaster's own chance of this, stated with the estimate: 10%; at least 8.1-fold (0.90 log units) between middle value and limit.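

In this assay, methoxy to hydroxy on the core of compound 2 gives an at least 10-fold higher number from compound 2 to compound 4 (1.00 log units; beyond the scatter), and that size is only a lower bound: the limit of > 203000 nM in this assay, at which 1 of the 4 values shown sits.

The same change on the core of compound 1 cannot be read, with compound 1 and compound 3 both reported only as limits. The step is therefore shown on one core only, and whether it carries over to the core of compound 1, in size or in direction, is not shown.

The compounds shown leave open how an ethyl group or a longer chain on that oxygen would read in this assay. Also open, as far as these compounds go, is whether an amine in place of the methoxy would read like the hydroxy.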